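The compounds below may be only part of what the source reports. "The series", "measured", "known", "first", "only" and "open" are said of these compounds alone.

Compound 1 `O=c1cc(CSC(=S)N2CCCC2)oc2ccccc12` carries a pyrrolidin-1-yl on a thiocarbonyl carbon. In a functional assay on MDA-MB-435S cells (Homo sapiens) for antiproliferative activity, read by MTT assay, with a stated time of 72 h (a higher number here means a weaker inhibitor, a lower number a stronger inhibitor), compound 1 gives only a limit, > 30000 nM. Compound 2 `O=c1cc(CSC(=S)N2CCCCC2)oc2ccccc12` shows (piperidin-1-yl in place of pyrrolidin-1-yl on a thiocarbonyl carbon); in this assay compound 2 also gives only a limit, > 25000 nM. The step that the two limits leave unreadable from compound 1 to compound 2 therefore has no readable size. Compound 3 `COc1ccc2occ(CSC(=S)N3CCCC3)c(=O)c2c1` rests on a different core; the difference between the two cores is not broken down here. In this assay compound 3 gives 1800 nM. Compound 4 `COc1ccc2occ(CSC(=S)N3CCCCC3)c(=O)c2c1` is not yet measured and differs from compound 3 by piperidin-1-yl in place of pyrrolidin-1-yl on a thiocarbonyl carbon, the same change at the same place as seen between compound 1 and compound 2. That earlier step gives no size, so the expectation rests on compound 3 with 1800 nM alone, and a small, uncertain step a 1.4-fold higher number from compound 3 to compound 4 (0.14 log units; within the scatter) is expected. Compound 4 is estimated at 2500 nM, likely between 800 nM and 8000 nM.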

Compound 4, half-maximal inhibitory concentration: 930 nM
Compound 4: middle estimate off by 2.7-fold (0.43 log units), on the high side, and the stated range covers the measured number.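

On the core of compound 3, piperidin-1-yl in place of pyrrolidin-1-yl on a thiocarbonyl carbon gives a 1.9-fold lower number from compound 3 to compound 4 (0.29 log units; within the scatter), so in this assay the two rings cannot be told apart on this core. On the core of compound 1, compound 1 and compound 2 both give only limits, so the same change has no readable size there. The series therefore does not show whether the change carries from one core to the other; it offers one readable step, not a comparison of two.

Still open, going by these compounds, is how a morpholin-4-yl or a diethylamino group on the thiocarbonyl carbon would read in this assay. Also open, on these data alone, is how much each part of the difference between the two cores contributes.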